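This account rests on a few compounds, and the source may have more. Where it says the series, first, only, none or still open, it means among the compounds named here.

Within the data shown here, in an assay for inhibition of histone deacetylase 4 (Homo sapiens) (a higher number here means a weaker inhibitor, a lower number a stronger inhibitor), compound 2 `O=C(c1ccc(-c2nc(-c3cccs3)no2)s1)C(F)(F)F` gives 95 nM, the highest of the two numbers so far. Compound 1 `O=C(c1ccc(-c2nc(Cc3cccs3)no2)s1)C(F)(F)F` gives 15 nM. Among the measured compounds shown here, the only measured step, a 6.3-fold higher number from compound 1 to compound 2 (0.80 log units; beyond the scatter), concerned the link to the thiophen-2-yl group rather than the ring itself. Compound 3 `Cc1cccc(-c2noc(-c3ccc(C(=O)C(F)(F)F)s3)n2)c1` differs from compound 2 by 3-methylphenyl in place of thiophen-2-yl on an aromatic carbon. For the measured compounds named here, no measured step covers a swap of this ring, so the direction is uncertain. The step of a 1.1-fold higher number from compound 2 to compound 3 (0.02 log units; within the scatter) is expected to stay within the scatter. The estimate for compound 3 is 100 nM, with a range from 30 nM to 400 nM.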

Compound 3, half-maximal inhibitory concentration: 280 nM
For compound 3 the middle estimate is 2.8-fold (0.45 log units) below the measured one, within the range that was stated.
By their numbers in this assay, from the lowest: compound 1; then compound 2; then compound 3.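

The ring on this carbon matters: 3-methylphenyl in place of thiophen-2-yl gives a 2.9-fold higher number from compound 2 to compound 3 (0.47 log units; beyond the scatter), so this position does not treat these two aromatic rings alike. Measured against the (thiophen-2-yl)methyl group, the same ring gives a 19-fold higher number from compound 1 to compound 3 (1.27 log units; beyond the scatter), which leaves compound 1 with the lowest number of the three. Nothing available explains either step. 

From the compounds shown here alone, the ring and its methyl changed together, so their shares of the step stay unknown, and an unsubstituted phenyl would separate them. Also open, going by these compounds, is whether a (3-methylphenyl)methyl group would bring the number back down towards that of compound 1.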